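Notes on the benzenesulfonamide series in the cell assay

The compounds below may be only part of what the source reports. "The series", "measured", "known", "first", "only" and "open" are said of these compounds alone.

Compound 2 `CC(C)(O)c1cn(Cc2nnc(-c3cc(S(N)(=O)=O)c(SCc4ccccc4)cc3Cl)o2)nn1` gives the lowest of the three numbers in a functional assay on HCT-116 cells (Homo sapiens) for cytotoxicity, read by MTT assay, with a stated time of 72 h (a higher number here means a weaker inhibitor, a lower number a stronger inhibitor), at 82000 nM. Compound 1 `NS(=O)(=O)c1cc(-c2nnc(CN3CCN(c4ccccc4)CC3)o2)c(Cl)cc1SCc1ccccc1` gives 105000 nM in this assay, and compound 3 `COc1ccc(-c2cn(Cc3nnc(-c4cc(S(N)(=O)=O)c(SCc5ccccc5)cc4Cl)o3)nn2)cc1` gives 190000 nM. Both changes at the same position were small: a 1.3-fold lower number from compound 1 to compound 2 (0.11 log units; within the scatter), and a 2.3-fold higher number from compound 2 to compound 3 (0.36 log units; beyond the scatter). Compound 4 `NS(=O)(=O)c1cc(-c2nnc(/C=C/c3cccc(Cl)c3)o2)c(Cl)cc1SCc1ccccc1` carries 2-(3-chlorophenyl)ethenyl in place of (4-(1-hydroxy-1-methylethyl)-1H-1,2,3-triazol-1-yl)methyl on an aromatic carbon. The two measured steps at this position bear on the change; neither is large, and the entering group is unlike either of them, so no step beyond the scatter is expected in this assay, in either direction. Compound 4 is therefore estimated at 90000 nM, with a range of 30000 nM to 270000 nM, meaning an expected step of a 1.1-fold higher number from compound 2 to compound 4 (0.04 log units; within the scatter).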

Compound 4, half-maximal inhibitory concentration: 12000 nM
The estimate for compound 4 lay 7.5-fold (0.88 log units) above the measured number, and the stated range ends above it.
By their numbers in this assay, from the lowest: compound 4; then compounds 2, 1 and 3 (each within the scatter of the next, the first and the last beyond it).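

At this position, next to the ring oxygen, 2-(3-chlorophenyl)ethenyl in place of (4-(1-hydroxy-1-methylethyl)-1H-1,2,3-triazol-1-yl)methyl gives in this assay a 6.8-fold lower number from compound 2 to compound 4 (0.83 log units; beyond the scatter), a larger step than either earlier one. Going by these compounds alone, the position therefore responds more strongly than the earlier compounds showed, and the change removes the triazole, its hydrogen-bond donor and its acceptors while adding a double bond and chlorine. No supporting data explain this step.

The double bond and the chlorine remain unseparated. A plain 2-phenylethenyl group and a saturated 2-(3-chlorophenyl)ethyl chain would each test one of them.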